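Methylating the Ring Amide Nitrogen of Compound 2

This account rests on a few compounds, and the source may have more. Where it says the series, first, only, none or still open, it means among the compounds named here.

Going by the values given here, in a functional assay on MDA-MB-231 cells (Homo sapiens) for inhibition, read by MTT assay, with a stated time of 72 h (on this read-out higher numbers stand for weaker inhibition and lower numbers for stronger inhibition), compound 2 `COc1c(C)cnc(Cn2cc(C#CCCNc3cccc4c3C(=O)N(C3CCC(=O)NC3=O)C4=O)c3c(Cl)nc(N)nc32)c1C` gives 3530 nM, the only number measured so far. Compound 1 `COc1cc(C(=O)NCCCC#Cc2cn(Cc3ncc(C)c(OC)c3C)c3nc(N)nc(Cl)c23)ccc1NC(=O)[C@@H]1N[C@@H](CC(C)(C)C)[C@](C#N)(c2ccc(Cl)cc2F)[C@H]1c1cccc(Cl)c1F` reaches only a limit of this assay, > 100000 nM, and not a number. Compound 3 `COc1c(C)cnc(Cn2cc(C#CCCNc3cccc4c3C(=O)N(C3CCC(=O)N(C)C3=O)C4=O)c3c(Cl)nc(N)nc32)c1C` differs from compound 2 in a single place: methyl in place of hydrogen on an amide-type nitrogen in a ring. Among the compounds with values here, no step between two measured compounds is available, so the expectation rests on this change alone. A large step toward weaker inhibition is expected, an 11-fold higher number from compound 2 to compound 3 (1.05 log units; beyond the scatter), with a fair chance that only a limit is reported. For compound 3 the estimate is 40000 nM, ranging from 8000 nM to 150000 nM.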

Compound 3, half-maximal inhibitory concentration: 7770 nM
Compound 3: the middle estimate sits 5.1-fold (0.71 log units) above what was measured, and the stated range ends above it.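

In this assay, putting a methyl on the amide-type nitrogen, which turns 2,6-dioxopiperidin-3-yl into 1-methyl-2,6-dioxopiperidin-3-yl, gives a 2.2-fold higher number from compound 2 to compound 3 (0.34 log units; beyond the scatter). Compound 3 still gives a number and not a limit, so inhibition of these cells survives the loss of the amide hydrogen, though it is modestly weaker. Nothing measured on these compounds accounts for the size of this step. On these data alone, whether an ethyl or a longer chain ending in an amine on this nitrogen would weaken inhibition further remains open. As far as these compounds go, whether compound 2 and compound 3 inhibit these cells in the same way also remains open.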